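Shortening the Hydroxycarbamoyl Chain of Compound 3

The source may report more compounds than this note shows. Statements on the series, on what has been measured and on what is new or still open speak of the compounds shown alone.

Measured in a functional assay on MDA-MB-231 cells (Homo sapiens) for inhibition, read by MTT assay, with a stated time of 48 h; a lower number here means a stronger inhibitor, a higher number a weaker inhibitor:
- Compound 1 `O=C(CCCCCNC(=O)Cn1cnc2c(Nc3ccccc3)ncnc21)NO`: 22300 nM
- Compound 2 `O=C(CCCCNC(=O)Cn1cnc2c(Nc3ccccc3)nc(Nc3ccccc3)nc21)NO`: 11100 nM
- Compound 3 `O=C(CCCCCCNC(=O)Cn1cnc2c(Nc3ccccc3)ncnc21)NO`: 8910 nM

Compound 3 cannot be told apart from compound 2 within the usual scatter, and it is clearly lower than compound 1. The unmeasured compound 4 `O=C(CCCCNC(=O)Cn1cnc2c(Nc3ccccc3)ncnc21)NO` keeps the core of compound 3 but has a shorter chain. Hydroxycarbamoyl replaces 2-(hydroxycarbamoyl)ethyl on a saturated chain carbon, four bonds along the chain from an amide-type nitrogen (hydroxycarbamoyl in place of 2-(hydroxycarbamoyl)ethyl on a saturated chain carbon, four bonds along the chain from an amide-type nitrogen).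

Going by the values given here, one measured step bears on this change. It is a 2.5-fold lower number from compound 1 to compound 3 (0.40 log units; beyond the scatter), where (hydroxycarbamoyl)methyl stands in place of hydroxycarbamoyl, so the longer chain gave the lower number. Compound 4 moves the opposite way, to a chain shorter than that of compound 1, so a higher number is expected in this assay. This expectation rests on a single pair, so it remains uncertain. The expected size of the change is a 3.4-fold higher number from compound 3 to compound 4 (0.53 log units; beyond the scatter). For compound 4 the estimated value is 30000 nM, with an expected range of 12000 nM to 70000 nM.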

Compound 4, half-maximal inhibitory concentration: > 50000 nM
Compound 4 ended at the assay's limit; the forecaster's own chance of this, stated with the estimate: 10%; at least 1.6-fold (0.22 log units) between middle value and limit.
By their numbers in this assay, from the lowest: compounds 3, 2 and 1 (each within the scatter of the next, the first and the last beyond it). At a limit, above all of these: compound 4.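

In this assay compound 4 gives > 50000 nM, a limit and not a number: the limit of > 50000 nM in this assay, at which 1 of the 4 values shown sits.

Before this result, chain length rested on a single pair; now the shortest chain also has the highest reading, with an at least 2.2-fold higher number from compound 1 to compound 4 (0.35 log units; beyond the scatter) and an at least 5.6-fold higher number from compound 3 to compound 4 (0.74 log units; beyond the scatter), so the three chains of compound 4, compound 1 and compound 3 fall in one order. Going by these compounds alone, the result also gives the first comparison for the second anilino group at a matched chain, since hydrogen in place of anilino on an aromatic carbon gives an at least 4.5-fold higher number from compound 2 to compound 4 (0.65 log units; beyond the scatter).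

As far as these compounds go, how far the true value of compound 4 lies past the limit stays unknown. Also open, from the compounds shown here alone, are whether a longer chain than that of compound 3 would lower the number further, and how a carboxylic acid in place of hydroxycarbamoyl would read.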